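Chlorophenyl for fluorophenyl on the ethyl core

The compounds below may be only part of what the source reports. "The series", "measured", "known", "first", "only" and "open" are said of these compounds alone.

Compound 3, `CCc1nn(C)c2c1C(c1ccc(F)cc1)=NCC(=O)N2`, stands at the weak end of the numbers seen so far: in a functional assay on the whole organism (strain Holtzman) with Rattus norvegicus as the target (on this read-out higher numbers stand for an effect only at larger amounts of compound and lower numbers for an effect already at smaller amounts), compound 3 gives only a limit, > 40 mg/kg, with no single number recorded; a further entry for compound 3 also holds no number. This limit is the point at which one of the three values sits, (the limit of > 40 mg/kg in this assay, at which 1 of the 3 values shown sits). The other two compounds give numbers. Compound 1, `Cc1nn(C)c2c1C(c1ccccc1Cl)=NCC(=O)N2`, gives 2.5 mg/kg in this assay. Compound 2, `CCc1nn(C)c2c1C(c1ccccc1F)=NCC(=O)N2`, gives 1.25 mg/kg; 1.25 mg/kg (2 entries) in this assay. Compound 1 and compound 2 differ in more than one place, so their values are taken only as they stand.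

Compound 4, `CCc1nn(C)c2c1C(c1ccccc1Cl)=NCC(=O)N2`, is the next to be measured. Compared with compound 3 the change is 2-chlorophenyl in place of 4-fluorophenyl on a carbon with a double bond to nitrogen. Within the data shown here, no measured step of this kind exists. Compound 2, carrying 2-fluorophenyl at the same place, and compound 1, carrying 2-chlorophenyl, both give numbers well inside the range, whereas compound 3 with 4-fluorophenyl gives only a limit; the expected step from compound 3 to compound 4 is therefore large, towards lower dose, an at least 26-fold lower number from compound 3 to compound 4 (1.42 log units; beyond the scatter), beyond the scatter. For compound 4 the estimate in this assay is 1.5 mg/kg, within 0.5 mg/kg to 5 mg/kg.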

Compound 4, minimum effective dose: 2.5 mg/kg
The estimate for compound 4 lay 1.7-fold (0.22 log units) below the measured number; the measured number falls inside the stated range.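

In this assay, among these compounds, 2-chlorophenyl in place of 4-fluorophenyl on the carbon with a double bond to nitrogen gives an at least 16-fold lower number from compound 3 to compound 4 (1.20 log units; beyond the scatter) and is the first measured step at this place, which shows that the group held there can decide whether the ethyl core reads in the range at all. Compound 3 gives only a limit, so this step has a bound and not an exact size: the limit of > 40 mg/kg in this assay, at which 1 of the 4 values shown sits. Among the compounds shown here, at the other place, with 2-chlorophenyl held constant, methyl in place of hydrogen on the saturated chain carbon bound to an aromatic carbon gives no change at the digits printed from compound 1 to compound 4 (within the scatter) and is the first sign that ethyl and methyl read alike on this core, at least alongside this group.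

The step at the carbon changes both the halogen and where it stands on the ring, and a plain phenyl or a 4-chlorophenyl at this place would be needed to separate the two. From the compounds shown here alone, how a longer chain such as propyl, or a chain carrying an amine, would read in place of the ethyl also stays open.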